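The source may report more compounds than this note shows. Statements on the series, on what has been measured and on what is new or still open speak of the compounds shown alone.

Compound 1 `CC(=O)c1c(O)cc(O)cc1CCCCCCCCc1ccccc1` and compound 2 `CCCCCCCCCCCCCc1cc(O)cc(O)c1C(C)=O` share the same core and differ only in the tail of the chain. In a functional assay on MCF7 cells (Homo sapiens) for cytotoxicity, with a stated time of 7 days (a higher number here means that more compound is needed for the effect, a lower number that less compound is needed), compound 1 gives 3.44 ug/mL and compound 2 gives 1.12 ug/mL, the lower of the two numbers, so that a 3.1-fold lower number from compound 1 to compound 2 (0.49 log units; beyond the scatter). Compound 3 `CC(=O)c1c(O)cc(O)cc1CCCCCCCCCCc1ccccc1` differs from compound 2 by phenyl in place of propyl on a saturated chain carbon, ten or more bonds along the chain from an aromatic carbon. Among the measured compounds shown here, that earlier step, which swapped an aromatic ring for a saturated chain end, is the only guide and points the opposite way, so a modest rise is expected. For compound 3 the expected number is 2.5 ug/mL, between 1 ug/mL and 6 ug/mL, an estimated step of a 2.2-fold higher number from compound 2 to compound 3 (0.35 log units; beyond the scatter).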

Compound 3, concentration for half-maximal effect: 2.87 ug/mL
For compound 3 the middle estimate is 1.1-fold (0.06 log units) below the measured one; the measured number falls inside the stated range.
By their numbers in this assay, from the lowest: compound 2; then compounds 3 and 1 (each within the scatter of the next).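

With phenyl kept at the chain end, phenethyl in place of phenyl gives a 1.2-fold lower number from compound 1 to compound 3 (0.08 log units; within the scatter) in this assay and so shows no readable effect of this lengthening. Phenyl in place of propyl on a saturated chain carbon gives a 2.6-fold higher number from compound 2 to compound 3 (0.41 log units; beyond the scatter) and so leaves both phenyl-ended compounds on the higher side of compound 2. No evidence is available to explain these results. Going by these compounds, how an amine or a carboxylic acid at the chain end would compare remains open, as does the effect of a still longer phenyl-ended chain.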